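This account rests on a few compounds, and the source may have more. Where it says the series, first, only, none or still open, it means among the compounds named here.

Measured compounds in a functional assay on NIH3T3 cells (Mus musculus); on this read-out lower numbers stand for an effect already at smaller amounts and higher numbers for an effect only at larger amounts of compound:
- Compound 1 `COC(=O)[C@H](CCSC)NC(=O)c1ccc(CNCc2c[nH]cn2)cc1-c1ccccc1C` gives 25 uM.
- Compound 2 `CSCC[C@H](NC(=O)c1ccc(NCc2cncn2Cc2cccc(C)c2)cc1-c1ccccc1)C(=O)O` gives > 10 uM, which is a limit of the assay and not a number.
- Compound 3 `COC(=O)[C@H](CCSC)NC(=O)c1ccc(NCc2cncn2Cc2ccc(Cl)cc2)cc1-c1ccccc1` gives > 10 uM, likewise a limit rather than a number.

Compound 2 therefore stands at the limit of > 10 uM in this assay, at which 2 of the 3 values shown sit. For the measured compounds named here, compound 1 is the only compound of the three with an actual number in this assay, and since compound 2 shows only a limit, no numerical gap between compound 1 and compound 2 can be stated. Of compound 2 and compound 3 one can say only that both sit at the limit.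

Compound 4 `CSCC[C@H](NC(=O)c1ccc(NCc2cncn2Cc2cccc(C#N)c2)cc1-c1ccccc1)C(=O)O` differs from compound 2 in a single place: cyano in place of methyl on an aromatic carbon. Going by the values given here, no step between measured compounds is available to size such a change, so the expectation rests on compound 2 alone. Because compound 2 sits at the limit of > 10 uM in this assay, at which 2 of the 3 values shown sit, compound 4 is expected to remain close to that limit. The step from compound 2 to compound 4 is expected to be small, a step that the limit leaves unreadable from compound 2 to compound 4, not beyond the scatter in either direction. Compound 4 is estimated at 20 uM, with a range from 8 uM to 60 uM.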

Compound 4, concentration for half-maximal effect: > 10 uM
Compound 4: only a limit was reported; the forecaster's own chance of this, stated with the estimate: 70%; the middle value lies beyond the limit too.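

No step can be read from compound 2 to compound 4 in this assay, because each of the two compounds shows only a limit of the assay and not a number: the limit of > 10 uM in this assay, at which 3 of the 4 values shown sit.

The compounds shown leave open whether cyano in place of methyl on an aromatic carbon changes the value in this assay, and in which direction and by how much.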